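Propyl for tert-butoxy on the carbonyl of compound 2

The source may report more compounds than this note shows. Statements on the series, on what has been measured and on what is new or still open speak of the compounds shown alone.

Compound 1 `CC1=C(C(=O)OC(C)(C)C)C(c2cccs2)NC(=O)N1` gives 38% in an assay on membranes from HEK293 cells for displacement of a labelled ligand from adenosine receptor A2b (Homo sapiens), read by scintillation counting, with a stated time of 30 min, tested at 1 uM; a lower number here means less inhibition, a higher number more inhibition at the concentration tested (going by the name of the read-out). Compound 2 `CC1=C(C(=O)OC(C)(C)C)C(c2ccsc2)NC(=O)N1` gives 47%, and compound 3 `CC1=C(C(=O)OC(C)(C)C)C(c2ccsc2)NC(=O)N1C` gives 35%. Compound 2 holds the highest of the three numbers: the step of a number 9 percentage points higher from compound 1 to compound 2 (within the scatter) lies within the scatter, while a number 12 percentage points lower from compound 2 to compound 3 (beyond the scatter) lies beyond it. Compound 4 `CCCC(=O)C1=C(C)NC(=O)NC1c1ccsc1` has not been measured. It differs from compound 2 by propyl in place of tert-butoxy on a carbonyl carbon. Neither measured step touches this carbonyl carbon; one concerns the saturated ring carbon, the other the amide-type nitrogen in the ring, and the two variations at those places moved the number by a small and a modest amount. For the measured compounds named here, there is no precedent at the carbonyl carbon in this set, and the expectation can only be loose. A modest downward step beyond the scatter is expected, a number 12 percentage points lower from compound 2 to compound 4 (beyond the scatter), with a wide range on either side. Compound 4 is accordingly estimated at 35%, between 10% and 60%.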

Compound 4, a percentage reported as inhibition, at one concentration (the size of the read-out at that concentration, not a potency): 9%
The estimate for compound 4 lay 26 percentage points above the measured number, and the stated range ends above it.
By their numbers in this assay, from the lowest: compound 4; then compounds 3, 1 and 2 (each within the scatter of the next, the first and the last beyond it).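

In this assay, for the compounds shown here, propyl in place of tert-butoxy on the carbonyl carbon gives a number 38 percentage points lower from compound 2 to compound 4 (beyond the scatter) and is the only large step so far, so this position responds more strongly to the change made here than the saturated ring carbon or the amide-type nitrogen did to theirs. Going by these compounds alone, the single swap removes the oxygen attached to the carbonyl carbon and also replaces the branched tert-butoxy with an unbranched chain, so the step reflects both differences together and cannot assign the loss to either one. No available evidence bears on the reason for the drop.

Propoxy on the same carbonyl carbon would keep the oxygen with an unbranched chain, while tert-butyl would keep the branching without the oxygen. From the compounds shown here alone, whether either retains the number of compound 2 remains open.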